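The compounds below may be only part of what the source reports. "The series", "measured", "known", "first", "only" and "open" are said of these compounds alone.

Three compounds share one core and differ only in the group carried on the saturated chain carbon bound to an amide-type nitrogen and a carbonyl carbon. Compound 1 `CC(NC(=O)c1ccc(C#Cc2ccccc2)cc1)C(=O)NO` carries a methyl there, compound 2 `O=C(N[C@H](CO)C(=O)NO)c1ccc(C#Cc2ccccc2)cc1` a hydroxymethyl, and compound 3 `O=C(CNC(=O)c1ccc(C#Cc2ccccc2)cc1)NO` a hydrogen. In a physicochemical assay for solubility (on this read-out lower numbers stand for lower solubility and higher numbers for higher solubility), compound 1 gives 29000 nM. Compound 2 gives 36000 nM in this assay, and compound 3 gives 21000 nM. The three numbers sit close together: the step of a 1.2-fold higher number from compound 1 to compound 2 (0.09 log units; within the scatter) is within the scatter, as are a 1.4-fold lower number from compound 1 to compound 3 (0.14 log units; within the scatter) and a 1.7-fold lower number from compound 2 to compound 3 (0.23 log units; within the scatter). Compound 3 is therefore not set apart from either neighbour in this assay.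

Compound 4 `CC(C)C(NC(=O)c1ccc(C#Cc2ccccc2)cc1)C(=O)NO` is the next member of the series. Its difference from compound 3 is isopropyl in place of hydrogen on a saturated chain carbon bound to an amide-type nitrogen and a carbonyl carbon. Going by the values given here, the steps that bear on this change are the two that also alter the group on this same carbon, a 1.4-fold lower number from compound 1 to compound 3 (0.14 log units; within the scatter) and a 1.7-fold lower number from compound 2 to compound 3 (0.23 log units; within the scatter), and both are within the scatter. There is no measured case in which a larger carbon group enters at this place, so any expectation rests on those two small steps. On that basis the expected step of a 1.2-fold lower number from compound 3 to compound 4 (0.07 log units; within the scatter) is one within the scatter. For compound 4 the expected value in this assay is 18000 nM, in a range from 8000 nM to 40000 nM.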

Compound 4, solubility: 7000 nM
The estimate for compound 4 lay 2.6-fold (0.41 log units) above the measured number, outside the stated range (below it).
By their numbers in this assay, from the lowest: compound 4; then compounds 3, 1 and 2 (each within the scatter of the next).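

Going by these compounds alone, at the saturated chain carbon bound to an amide-type nitrogen and a carbonyl carbon, hydrogen, methyl and hydroxymethyl gave numbers within the scatter of one another in this assay, and isopropyl is the first group here to move the number beyond it. The drop appears against all three earlier groups: a 3.0-fold lower number from compound 3 to compound 4 (0.48 log units; beyond the scatter) when isopropyl replaces hydrogen, a 4.1-fold lower number from compound 1 to compound 4 (0.62 log units; beyond the scatter) when it replaces methyl, and a 5.1-fold lower number from compound 2 to compound 4 (0.71 log units; beyond the scatter) when it stands where hydroxymethyl stood, so this place is not indifferent to the group it carries, although each step is only modest. Nothing measured in this set speaks to why the number falls with isopropyl.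

A single branched group cannot show whether the branching or the number of carbons goes with the lower number, and a straight propyl chain at this carbon would help to separate the two. From the compounds shown here alone, it also remains open where a group of another kind, such as an aminomethyl group or a carboxylic acid, would fall in this assay relative to compound 3 and compound 4.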